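The source may hold more compounds than are shown below. What is called first, only, known or untested is meant among the compounds shown, and "the series" means these compounds.

Measured in an ADME assay on DU-145 cells (Homo sapiens) for cytotoxicity, read by MTT assay, with a stated time of 72 h; on this read-out higher numbers stand for weaker inhibition and lower numbers for stronger inhibition:
Compound 1 `COc1ccc(C2=C(c3cc(OC)c(OC)c(OC)c3)C(=O)CC2O[SiH2]C(C)(C)C)cc1OC`: > 100 ug/mL (a limit)
Compound 2 `CC(=O)OC1C/C(=N/O)C(c2ccccc2)=C1c1ccccc1`: > 100 ug/mL (a limit)

Neither measured compound gives a number. Compound 2 stands at > 100 ug/mL, which is a limit of the assay. Compound 1 is also reported only as a limit. Among the compounds with values here, the series so far therefore sits at the limit of > 100 ug/mL in this assay, at which 2 of the 2 values shown sit.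

The next compound is compound 3 `O/N=C1/CC(O)C(c2ccccc2)=C1c1ccccc1`. It differs from compound 2 by hydrogen in place of acetyl on an oxygen on a saturated carbon, which reads as acetoxy to hydroxy (see (hydrogen in place of acetyl on an oxygen on a saturated carbon)).

With only limits available, the data give no measured size for any step and no measured effect for this change. The expectation rests on compound 2 at > 100 ug/mL, a limit. The expected change in this assay is a number no higher from compound 2 to compound 3 (the limit leaves the size open), which means no step beyond the scatter and no favoured direction. A further report as a limit is expected to be the most likely outcome.

Compound 3 is estimated at 100 ug/mL, with an expected range from 40 ug/mL to 200 ug/mL.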

Compound 3, half-maximal inhibitory concentration: > 100 ug/mL
Compound 3: a limit, no number; the forecaster's own chance of this, stated with the estimate: 70%; the middle value lies on the limit itself.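

No step can be read from compound 2 to compound 3 in this assay, because both compounds are reported only as limits: the limit of > 100 ug/mL in this assay, at which 3 of the 3 values shown sit.

The compounds shown leave open whether acetoxy to hydroxy has any effect on the read-out, and which structures, if any, would give an actual number in this assay.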